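The source may report more compounds than this note shows. Statements on the series, on what has been measured and on what is new or still open speak of the compounds shown alone.

Working notes on the series. The three measured compounds share one core carrying an aryl-substituted saturated chain; they differ in the arene on that chain and in the substitution of the core. Compound 1 `Fc1ccc(CC2(c3ccc4[nH]ccc4c3)CCNC2)cc1` is measured in an assay on isolated protein for inhibition of sodium-dependent dopamine transporter (Homo sapiens) (a higher number here means a weaker inhibitor, a lower number a stronger inhibitor), and gives 79 nM. Compound 2 `COc1cccc(CC2(c3ccc4[nH]ccc4c3)CCNC2)c1` gives 39 nM in this assay, and compound 3 `NC(=O)c1cc2cc(C3(Cc4ccccc4)CCNC3)ccc2[nH]1` gives 18 nM. Compound 1 thus stands with the highest number of the three: its gap to compound 2 and its wider gap to compound 3 both lie beyond the scatter, so compound 1 is the weakest inhibitor among the measured set.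

Compound 4 `CC1(c2ccc3[nH]ccc3c2)CCNC1` is not yet measured. It differs from compound 1 by hydrogen in place of 4-fluorophenyl on a saturated chain carbon bound to a saturated ring carbon, which removes the arene from the chain and leaves only a methyl on the saturated ring carbon. Among the compounds with values here, no measured pair in the set isolates this change, so its size can only be estimated from what the aryl variants show. For compound 4 the step of an 11-fold higher number from compound 1 to compound 4 (1.06 log units; beyond the scatter) is expected to run toward a higher number, beyond the scatter, since every measured compound carries an arene on that chain. The estimate for compound 4 is 900 nM, with a range from 150 nM to 5000 nM.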

Compound 4, inhibition constant: 550 nM
Compound 4: middle estimate off by 1.6-fold (0.21 log units), on the high side, and the stated range covers the measured number.
By their numbers in this assay, from the lowest: compound 3; then compound 2; then compound 1; then compound 4.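

Within the data shown here, the first single-place step comes from the chain: in this assay, hydrogen in place of 4-fluorophenyl on a saturated chain carbon bound to a saturated ring carbon gives a 7.0-fold higher number from compound 1 to compound 4 (0.84 log units; beyond the scatter). Among these compounds, the 4-fluorophenyl at this position therefore goes with a lower number, which the earlier compounds could not show because all of them carry an arene on that chain, yet its removal does not abolish inhibition, since compound 4 still gives 550 nM. No measurement at hand accounts for the size of this step.

The compounds shown do not separate the contribution of the arene from that of a saturated group, so it remains open whether a cyclohexyl ring or a longer alkyl chain such as propyl in place of 4-fluorophenyl would keep the number near that of compound 1 or move it towards that of compound 4. Also open, on these data alone, is how an amine or a carboxylic acid at the end of that chain would change the number on this core.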